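Replacing a methoxy with phenyl on an inactive ester

The source may report more compounds than this note shows. Statements on the series, on what has been measured and on what is new or still open speak of the compounds shown alone.

Of the compounds shown here, three sharing one core have been tested in a functional assay on MDA-MB-231 cells (Homo sapiens) for cytotoxicity, read by MTT assay, with a stated time of 48 h; on this read-out higher numbers stand for weaker inhibition and lower numbers for stronger inhibition. Compound 1 `O=C(NCc1ccccc1)c1cn(-c2ccccc2)nc1-c1cccnc1` carries a benzylamino group on its carbonyl carbon; compound 1 gives > 100000 nM, which is a limit of the assay rather than a number. Compound 2 `COc1ccc(OC(=O)c2cn(-c3ccccc3)nc2-c2cccnc2)cc1` replaces that group with a 4-methoxyphenoxy; compound 2 gives > 100000 nM, again a limit. Compound 3 `Cc1ccc(C(C)C)c(OC(=O)c2cn(-c3ccccc3)nc2-c2cccnc2)c1` bears a 2-isopropyl-5-methylphenyl on the oxygen beside the carbonyl; compound 3 gives > 100000 nM, also a limit. Because (the limit of > 100000 nM in this assay, at which 3 of the 3 values shown sit), neither a step that the two limits leave unreadable from compound 1 to compound 2 nor a step that the two limits leave unreadable from compound 2 to compound 3 can be read as a size or a direction: both steps run between two limits and show only that none of the three compounds inhibits within the range of this assay.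

Compound 4 `O=C(Oc1ccc(-c2ccccc2)cc1)c1cn(-c2ccccc2)nc1-c1cccnc1` is not yet measured. It differs from compound 2 by phenyl in place of methoxy on an aromatic carbon. Within the data shown here, since every measured step here sits at the same limit, no measured step gives any guidance on the size or direction of this change, and compound 2 itself stands only at a limit. With nothing pointing to a gain, compound 4 is expected to stay in the same inactive range, at an estimated 100000 nM within 30000 nM to 300000 nM, meaning an expected step of a number no higher from compound 2 to compound 4 (the limit leaves the size open) that most likely again returns only a limit.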

Compound 4, half-maximal inhibitory concentration: > 100000 nM
Compound 4 ended at the assay's limit; the forecaster's own chance of this, stated with the estimate: 75%; the middle value sits exactly at the limit.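

The change from methoxy to phenyl between compound 2 and compound 4 cannot be read as a size or a direction, since both compounds give only a limit, and this holds for all the compounds shown: the limit of > 100000 nM in this assay, at which 4 of the 4 values shown sit. What the compounds shown leave open is which change to the shared core, if any, gives a real number in this assay rather than a limit.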